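The source may report more compounds than this note shows. Statements on the series, on what has been measured and on what is new or still open speak of the compounds shown alone.

Compounds measured so far:
compound 1 `CCCCCCCCCCCCCCCOC(=O)CCC(=O)N1CCN(CCCOc2cc3c(Nc4ccc(F)c(Cl)c4)ncnc3cc2OC)CC1` — 91.2%
compound 2 `CCCCCCCCCCCCCCCCCCCOC(=O)CCC(=O)N1CCN(CCCOc2cc3c(Nc4ccc(F)c(Cl)c4)ncnc3cc2OC)CC1` — 94.8%

Both carry the same core; they differ only in the length of the saturated chain attached through the oxygen next to a carbonyl group. In a functional assay on A549 cells (Homo sapiens) for cytotoxicity, read by MTT assay, with a stated time of 24 h, tested at 20 uM (on this read-out lower numbers stand for a stronger effect and higher numbers for a weaker effect at the one concentration tested), compound 1 gives 91.2% and compound 2 gives 94.8%. Compound 2 holds the highest of the two numbers, but the gap to compound 1 is within the scatter, so no order can be read from it: the step of a number 3.6 percentage points higher from compound 1 to compound 2 (within the scatter) is flat.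

Compound 3 `CCCCCCCCCCCCCCCCCCCCOC(=O)CCC(=O)N1CCN(CCCOc2cc3c(Nc4ccc(F)c(Cl)c4)ncnc3cc2OC)CC1` is the next member of the chain series. It differs from compound 2 as methyl in place of hydrogen on a saturated chain carbon, ten or more bonds along the chain from an oxygen next to a carbonyl group. Going by the values given here, the only measured step that bears on this change is the chain lengthening from compound 1 to compound 2, butyl in place of hydrogen at the same kind of position, which gave a number 3.6 percentage points higher from compound 1 to compound 2 (within the scatter). A single methyl added at that distance from the oxygen next to a carbonyl group is a smaller change than the butyl step, and that larger step moved nothing beyond the scatter. No step beyond the scatter is therefore expected in this assay: the expected step is a number 0.8 percentage points lower from compound 2 to compound 3 (within the scatter). Compound 3 is estimated at 94%, with a range of 84% to 104%.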

Compound 3, a percentage reported as activity, at one concentration (the size of the read-out at that concentration, not a potency): 90.8%
Compound 3: middle estimate off by 3.2 percentage points, on the high side, and the stated range covers the measured number.
By their numbers in this assay, from the lowest: compounds 3, 1 and 2 (each within the scatter of the next).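

In this assay, the methyl change on a saturated chain carbon reads as a number 4 percentage points lower from compound 2 to compound 3 (within the scatter), so this smallest chain change in the series is flat as well. The pentyl change at the same kind of place reads as a number 0.4 percentage points lower from compound 1 to compound 3 (within the scatter); with it, the methyl, butyl and pentyl steps are all within the scatter, and no order by chain length can be read across compound 1, compound 2 and compound 3. No measurement at hand bears on why these chain changes leave this read-out flat.

The compounds shown leave open whether a much shorter chain, such as ethyl, or a carboxylic acid in place of the long chain ester would give a step beyond the scatter in this assay. They also leave open whether an amine at the end of the long chain, or a chain carrying a ring, would separate from these three compounds on the shared core.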